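A few compounds are considered here, and "the series" means these few. Any claim that something is new, unique, unknown or untested is made for them only; others in the source may bear on it.

Compound 1 `CC(=O)Nc1ccc(Cc2noc(CCC(=O)O)n2)cc1`: 75.3%
Compound 2 `CC(=O)Nc1ccc(Cc2noc(CCC(=O)Nc3ccc(F)cc3F)n2)cc1`: 52.1%

Both were tested in a functional assay on the whole organism (strain C57BL/6) for inhibition, with Mus musculus as the target, read by paw edema, with stated times of 1 h and 4 h, at a dose of 100 mg/kg by the oral route; on this read-out lower numbers stand for less inhibition and higher numbers for more inhibition at the one dose given (going by the name of the read-out). Compound 1 gives 75.3%, and compound 2 gives 52.1%. For the measured compounds named here, compound 2 stands lowest of the two numbers, and the single measured step, a number 23.2 percentage points lower from compound 1 to compound 2 (beyond the scatter), separates it from compound 1 and lies beyond the scatter.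

Compound 3 `CC(=O)Nc1ccc(Cc2noc(CCC(=O)Nc3cccc(C)c3)n2)cc1` has not yet been measured. It differs from compound 2 in one place: 3-methylphenyl in place of 2,4-difluorophenyl on an amide-type nitrogen. Going by the values given here, no measured step bears on this exchange. Among the compounds with values here, the only step recorded, a number 23.2 percentage points lower from compound 1 to compound 2 (beyond the scatter), puts (2,4-difluorophenyl)amino in place of hydroxy on a carbonyl carbon and so says nothing about trading one aryl group for another on the amide-type nitrogen. Because compound 2 gives 52.1% and the data offer no guide to the size or direction of this change, compound 3 is expected to show a step of a number 0.1 percentage points lower from compound 2 to compound 3 (within the scatter), which is no more than the scatter. The estimate for compound 3 is 52%, expected to fall between 35% and 70%.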

Compound 3, a percentage reported as inhibition, in the whole organism at one dose (the size of the read-out at that dose, not a potency): 16.4%
Compound 3: the middle estimate sits 35.6 percentage points above what was measured; the measured number lies below the stated range.
By their numbers in this assay, from the lowest: compound 3; then compound 2; then compound 1.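

In this assay, the aryl group on the amide-type nitrogen turns out to matter greatly: 3-methylphenyl in place of 2,4-difluorophenyl gives a number 35.7 percentage points lower from compound 2 to compound 3 (beyond the scatter), although both groups hold one six-membered aromatic ring of carbon only, with no hydrogen-bond donors or acceptors and no net charge. The change away from hydroxy on the carbonyl carbon therefore depends on the group that enters, with (3-methylphenyl)amino giving a number 58.9 percentage points lower from compound 1 to compound 3 (beyond the scatter), whereas (2,4-difluorophenyl)amino gave a number 23.2 percentage points lower from compound 1 to compound 2 (beyond the scatter). Nothing available explains why these two aryl groups part so widely in this read-out.

The compounds shown leave open whether the drop follows the loss of the two fluorines or the arrival of the methyl, since both happen in this one exchange, and a plain phenyl on the amide-type nitrogen would separate the two. They also leave open how far the aromatic ring itself is needed in this assay, a question that a cyclohexyl group on that nitrogen would address.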